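Methyl for Methoxy on a Pyrazole Thiourea Series

The source may report more compounds than this note shows. Statements on the series, on what has been measured and on what is new or still open speak of the compounds shown alone.

Measured compounds:
Compound 1 `Cc1ccc(NC(=S)NC(=O)c2cn(-c3ccccc3)nc2-c2ccc(C)cc2)cc1`: 5660 nM
Compound 2 `O=C(NC(=S)Nc1ccc(F)cc1)c1cn(-c2ccccc2)nc1-c1ccccc1`: 6820 nM
Compound 3 `COc1ccc(-c2nn(-c3ccccc3)cc2C(=O)NC(=S)Nc2ccc(F)cc2)cc1`: 4990 nM

In a functional assay on MCF7 cells (Homo sapiens) for inhibition, read by CCK-8 assay, with a stated time of 48 h (on this read-out lower numbers stand for stronger inhibition and higher numbers for weaker inhibition), compound 3 gives 4990 nM, the lowest of the three numbers, though its nearest neighbour compound 1 at 5660 nM and the furthest, compound 2 at 6820 nM, both lie within the scatter of it, so no order among the three can be claimed. Compound 4 `Cc1ccc(-c2nn(-c3ccccc3)cc2C(=O)NC(=S)Nc2ccc(F)cc2)cc1` differs from compound 3 by methyl in place of methoxy on an aromatic carbon. For the measured compounds named here, the one step measured at that ring, a 1.4-fold lower number from compound 2 to compound 3 (0.14 log units; within the scatter), shows that adding methoxy there hardly moved the read-out. Going by the values given here, no pair directly compares methyl with methoxy at that position; compounds 1 and 2 carry methyl and hydrogen there but also differ at the aniline end, so the value of compound 1, 5660 nM, and that of compound 2, 6820 nM, only show that both sit near compound 3. Compound 4 is therefore expected to stay within the scatter, with a 1.1-fold higher number from compound 3 to compound 4 (0.04 log units; within the scatter) amounting to no real change. Compound 4 is estimated at 5500 nM, in the range 2500 nM to 12000 nM.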

Compound 4, half-maximal inhibitory concentration: 6420 nM
Estimate against measurement, compound 4: 1.2-fold (0.07 log units) below; the measured number falls inside the stated range.
By their numbers in this assay, from the lowest: compounds 3, 1, 4 and 2 (each within the scatter of the next).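

In this assay, the direct change from 4-methoxyphenyl to 4-methylphenyl gives a 1.3-fold higher number from compound 3 to compound 4 (0.11 log units; within the scatter), so methyl and methoxy at this position cannot be told apart. Methyl in place of hydrogen on the same carbon gives a 1.1-fold lower number from compound 2 to compound 4 (0.03 log units; within the scatter), which, together with a 1.4-fold lower number from compound 2 to compound 3 (0.14 log units; within the scatter), means hydrogen, methyl and methoxy there all read alike within the scatter. At the other end of the molecule, fluoro in place of methyl gives a 1.1-fold higher number from compound 1 to compound 4 (0.05 log units; within the scatter), so that change also shifts the read-out by no more than the scatter. Nothing available explains this flat behaviour at either place. From the compounds shown here alone, it remains open whether an amine, a carboxylic acid or a longer chain such as butoxy at this position would move the number beyond the scatter. The compounds shown also leave open whether any group at the aniline end would do so.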